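The compounds below may be only part of what the source reports. "The series", "measured", "known", "first", "only" and "open" are said of these compounds alone.

Of the compounds shown here, three built on a shared core have been measured for how readily they dissolve. Compound 1 `Cc1cc(C)cc(NC(=O)COc2cc(C)nc3ccc(C)cc23)c1` gives 83000 nM in a physicochemical assay for solubility, in phosphate buffer, measured as kinetic solubility, with a stated time of 1 h, at pH 7.4; on this read-out higher numbers stand for higher solubility and lower numbers for lower solubility. Compound 2 `COc1ccc2nc(C(F)(F)F)cc(OCC(=O)Nc3cc(C)cc(C)c3)c2c1` gives 15000 nM in this assay. Compound 3 `COc1ccc2nc(C)cc(OCC(=O)Nc3c(C)cccc3C)c2c1` gives 112000 nM in this assay, the largest of the three numbers; compound 1 lies so close that the two cannot be told apart, while compound 2 sits clearly lower. Compound 4 `COc1ccc2nc(C)cc(OCC(=O)Nc3c(C)cncc3C)c2c1` has not yet been measured. It differs from compound 3 in a single place: 3,5-dimethylpyridin-4-yl in place of 2,6-dimethylphenyl on an amide-type nitrogen. Within the data shown here, no pair of measured compounds differs in this same way, so no measured step shows the size of the effect to expect. Starting from compound 3 at 112000 nM, the step is expected to be a 1.8-fold higher number from compound 3 to compound 4 (0.25 log units; within the scatter), an increase that may only just reach beyond the scatter. Compound 4 is therefore estimated to give 200000 nM in this assay, with a range from 90000 nM to 450000 nM.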

Compound 4, solubility: 12000 nM
Compound 4: middle estimate off by 17-fold (1.22 log units), on the high side, and the stated range ends above it.
By their numbers in this assay, from the lowest: compounds 4 and 2 (each within the scatter of the next); then compounds 1 and 3 (each within the scatter of the next).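

Among these compounds, this is the first step that can be read as a single change, and it is a clear one: in this assay, 3,5-dimethylpyridin-4-yl in place of 2,6-dimethylphenyl on an amide-type nitrogen gives a 9.3-fold lower number from compound 3 to compound 4 (0.97 log units; beyond the scatter), beyond the scatter. The two groups have the same number of heavy atoms and differ only in that one ring carbon is replaced by a nitrogen, which adds a hydrogen-bond acceptor, so a small edit at this place goes with a large drop in the number. Nothing available here accounts for the direction or size of this step.

As far as these compounds go, this change rests on one pair of compounds, so whether it would give a similar step on another compound, such as compound 1, remains open. Also open, from the compounds shown here alone, is where other groups on this nitrogen would fall, such as a phenyl ring carrying an amine or a carboxylic acid.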